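This account rests on a few compounds, and the source may have more. Where it says the series, first, only, none or still open, it means among the compounds named here.

Measured compounds:
compound 1 `COc1cccc(-n2cc3nc(-c4cccnc4C)n(C[C@H]4CCCN(Cc5ccco5)C4)c(=O)c3n2)c1` — in an assay on HEK293 cells for displacement of a labelled ligand from growth hormone secretagogue receptor type 1 (Homo sapiens), with a stated time of 60 min (on this read-out lower numbers stand for stronger inhibition and higher numbers for weaker inhibition), compound 1 gives 2.7 nM
compound 2 `COc1cccc(-n2cc3nc(-c4cccnc4C)n(C[C@H]4CCCN(CC5CCOC5)C4)c(=O)c3n2)c1` — in this assay compound 2 gives 60 nM

Among the compounds with values here, compound 2 stands at the highest of the two numbers measured so far; the only neighbour is compound 1, and the step of a 22-fold higher number from compound 1 to compound 2 (1.35 log units; beyond the scatter) is large and beyond the scatter.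

Compound 3 `COc1cccc(-n2cc3nc(-c4cccnc4C)n(C[C@H]4CCCN(CC5CCCCO5)C4)c(=O)c3n2)c1` is the next member. It differs from compound 2 by oxan-2-yl in place of oxolan-3-yl on a saturated chain carbon bound to an amine nitrogen in a ring.

Within the data shown here, no measured step covers this exact change. Among the measured compounds shown here, the only step in the set, a 22-fold higher number from compound 1 to compound 2 (1.35 log units; beyond the scatter), concerns a furan-2-yl against a saturated oxolan-3-yl, not one saturated oxygen ring against another. That step shows the position is sensitive, but gives no direction for a ring-size change between two saturated rings. Compound 3 is therefore expected to stay near compound 2, with a step of a 1.3-fold lower number from compound 2 to compound 3 (0.12 log units; within the scatter) in this assay. Compound 3 is estimated at 45 nM, with a range from 12 nM to 170 nM.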

Compound 3, half-maximal inhibitory concentration: 120 nM
Compound 3: the middle estimate sits 2.7-fold (0.43 log units) below what was measured, within the range that was stated.
By their numbers in this assay, from the lowest: compound 1; then compounds 2 and 3 (each within the scatter of the next).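

In this assay, the two saturated oxygen rings, oxolan-3-yl and oxan-2-yl, are not separated by the step of a 2.0-fold higher number from compound 2 to compound 3 (0.30 log units; within the scatter), so the change in ring size and attachment point has no readable effect here. Against furan-2-yl, oxan-2-yl gives a 44-fold higher number from compound 1 to compound 3 (1.65 log units; beyond the scatter), a second large step that places furan-2-yl apart from both saturated rings and leaves compound 1 the most potent of the three. Nothing available here accounts for this gap.

From the compounds shown here alone, it remains open whether the low number belongs to furan-2-yl alone or extends to other aromatic rings, such as phenyl or thiophen-2-yl, on the same saturated chain carbon. Also open, going by these compounds, is how a ring without oxygen, such as cyclohexyl, compares with oxan-2-yl at this place.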